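Nitro in place of cyano on compound 2

This account rests on a few compounds, and the source may have more. Where it says the series, first, only, none or still open, it means among the compounds named here.

Compound 1 `CC(O)(CS(=O)(=O)c1ccccc1C(F)(F)F)C(=O)Nc1ccc(S(F)(F)(F)(F)F)cc1` gives 10800 nM
Compound 2 `CC1(C)C(=O)N(c2ccc(C#N)cc2C(F)(F)F)C(=S)N1c1cccc(S(F)(F)(F)(F)F)c1` gives 4100 nM

In a functional assay on LNCaP cells (Homo sapiens) for antiproliferative activity, read by propidium iodide staining, with a stated time of 96 h (on this read-out lower numbers stand for stronger inhibition and higher numbers for weaker inhibition), compound 2 gives 4100 nM and holds the lowest of the two numbers, with compound 1 higher at 10800 nM by more than the usual scatter. Compound 3 `CC1(C)C(=O)N(c2ccc([N+](=O)[O-])cc2C(F)(F)F)C(=S)N1c1cccc(S(F)(F)(F)(F)F)c1` differs from compound 2 in one place, with nitro in place of cyano on an aromatic carbon, meta to a trifluoromethyl group and para to a large group (nitro in place of cyano on an aromatic carbon). Among the measured compounds shown here, no measured pair shows this swap, so the data give no direct guide to its size. The rest of the structure stays the same, so no change beyond the scatter is expected in this assay and neither direction is favoured. The estimate therefore starts from compound 2 at 4100 nM and keeps a wide range. The expected move is a 1.0-fold lower number from compound 2 to compound 3 (0.01 log units; within the scatter) and stays small. For compound 3 an estimated 4000 nM is expected, within a range of 1500 nM to 11000 nM on repeated measurement.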

Compound 3, half-maximal inhibitory concentration: 5300 nM
Estimate against measurement, compound 3: 1.3-fold (0.12 log units) below; measured number inside the range.
By their numbers in this assay, from the lowest: compounds 2 and 3 (each within the scatter of the next); then compound 1.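

In this assay, among the compounds shown here, placing nitro where cyano stood, on an aromatic carbon meta to a trifluoromethyl group and para to a large group, gives a 1.3-fold higher number from compound 2 to compound 3 (0.11 log units; within the scatter) and is the first direct reading of this swap. This assay therefore does not separate the two groups at this position, and the larger nitro group, with its additional hydrogen-bond acceptor, leaves the read-out within the scatter of cyano. No measured evidence bears on why the two groups read alike here.

The compounds shown carry only cyano or nitro at this position, so how an amine, a carboxylic acid or a methyl ester would read there stays open. Going by these compounds, it is also open whether the swap would read alike with a chlorine in place of the trifluoromethyl group.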